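Trimming the acyl group of compound 3

This account rests on a few compounds, and the source may have more. Where it says the series, first, only, none or still open, it means among the compounds named here.

- compound 1 `COc1cc(/C=C2\CNC/C(=C\c3cc(OC)c(OC)c(OC)c3)C2=O)cc(OC)c1OC`: 7600 nM
- compound 2 `COc1cc(/C=C2\CN(C)C/C(=C\c3cc(OC)c(OC)c(OC)c3)C2=O)cc(OC)c1OC`: 26400 nM
- compound 3 `COc1cc(/C=C2\CN(C(=O)C(C)C)C/C(=C\c3cc(OC)c(OC)c(OC)c3)C2=O)cc(OC)c1OC`: 12200 nM

In an ADME assay on L02 cells (Homo sapiens) for cytotoxicity, read by MTT assay, with a stated time of 72 h (on this read-out lower numbers stand for stronger inhibition and higher numbers for weaker inhibition), compound 3 gives 12200 nM, the second highest of the three numbers. Its nearest neighbour is shown by a 1.6-fold higher number from compound 1 to compound 3 (0.21 log units; within the scatter), and its furthest by a 2.2-fold lower number from compound 2 to compound 3 (0.34 log units; beyond the scatter).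

Compound 4 `CCC(=O)N1C/C(=C\c2cc(OC)c(OC)c(OC)c2)C(=O)/C(=C/c2cc(OC)c(OC)c(OC)c2)C1` has not yet been measured. It differs from compound 3 in one place: hydrogen in place of methyl on a saturated chain carbon bound to a carbonyl carbon and a saturated chain carbon. Hydrogen stands in place of methyl on a saturated chain carbon bound to a carbonyl carbon and a saturated chain carbon, so isopropylcarbonyl becomes propanoyl.

Within the data shown here, no measured step makes this exact change, so the evidence is indirect. All three steps concern the group on the amine nitrogen in a ring. Putting the whole isopropylcarbonyl group on that nitrogen in place of hydrogen gives only a 1.6-fold higher number from compound 1 to compound 3 (0.21 log units; within the scatter). The modest steps, a 3.5-fold higher number from compound 1 to compound 2 (0.54 log units; beyond the scatter) and a 2.2-fold lower number from compound 2 to compound 3 (0.34 log units; beyond the scatter), both involve the methyl on that nitrogen, not a change within the acyl chain. A change of a single methyl within isopropylcarbonyl is therefore expected to produce no shift beyond the scatter.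

The expected step is a 1.1-fold lower number from compound 3 to compound 4 (0.03 log units; within the scatter). Compound 4 is estimated at 11500 nM, with an expected range from 5500 nM to 24000 nM.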

Compound 4, half-maximal inhibitory concentration: 4200 nM
Estimate against measurement, compound 4: 2.7-fold (0.44 log units) above; measured number below the stated range.
By their numbers in this assay, from the lowest: compounds 4, 1 and 3 (each within the scatter of the next, the first and the last beyond it); then compound 2.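

In this assay, among these compounds, the acyl chain itself now proves to count: hydrogen in place of methyl on a saturated chain carbon bound to a carbonyl carbon and a saturated chain carbon, which turns isopropylcarbonyl into propanoyl, gives a 2.9-fold lower number from compound 3 to compound 4 (0.46 log units; beyond the scatter) and so lies beyond the scatter, whereas the earlier steps had changed only the group on the amine nitrogen in a ring. On that nitrogen, propanoyl in place of methyl gives a 6.3-fold lower number from compound 2 to compound 4 (0.80 log units; beyond the scatter) as the largest step among these compounds. Propanoyl in place of hydrogen gives only a 1.8-fold lower number from compound 1 to compound 4 (0.26 log units; within the scatter) and so does not separate compound 4 from compound 1, which means the single methyl distinguishes compound 4 from compound 3 without moving compound 4 clear of the compound with hydrogen on the nitrogen.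

Nothing given here accounts for the effect of this one methyl on the read-out. On these data alone, how this assay would read for a shorter acetyl group, a longer butanoyl chain or an acyl chain carrying an amine stays open, so these few compounds do not yet describe a trend along the acyl chain.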